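The source may report more compounds than this note shows. Statements on the series, on what has been measured and on what is new or still open speak of the compounds shown alone.

In a functional assay on the whole organism for inhibition, with Cavia porcellus as the target (on this read-out lower numbers stand for an effect already at smaller amounts and higher numbers for an effect only at larger amounts of compound), compound 1 (`COc1ccccc1OCC1SCCN1C(=O)Cn1ccnc1`) gives 50 mg/kg, compound 2 (`COc1ccccc1OCC1SCCN1C(=O)C(C)(C)C(=O)O`) gives 34 mg/kg and compound 3 (`CNC(=O)CC(=O)N1CCSC1COc1ccccc1OC`) gives 21 mg/kg. Two steps fix the standing of that last value: a 1.6-fold lower number from compound 2 to compound 3 (0.21 log units; within the scatter), and a 2.4-fold lower number from compound 1 to compound 3 (0.38 log units; beyond the scatter). Compound 4 (`COc1ccccc1OCC1SCCN1C(=O)CC(=O)NCc1cccnc1`) carries the change (pyridin-3-yl in place of hydrogen on a saturated chain carbon bound to an amide-type nitrogen), so methylamino becomes ((pyridin-3-yl)methyl)amino. Going by the values given here, no measured step alters this amide substituent, and the data hold no direct precedent for it. Among the compounds with values here, the only guidance comes from changes elsewhere in the same side chain, namely a 1.5-fold lower number from compound 1 to compound 2 (0.17 log units; within the scatter), together with the two steps above. Even the largest of these is modest, so the whole series so far spans a narrow range. Within the data shown here, on that basis no step much beyond the scatter is expected, and the data favour no direction. The expected change is a 1.2-fold higher number from compound 3 to compound 4 (0.08 log units; within the scatter). Compound 4 is estimated at 25 mg/kg, with an expected range of 10 mg/kg to 60 mg/kg.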

Compound 4, dose for half-maximal effect: 57 mg/kg
Estimate against measurement, compound 4: 2.3-fold (0.36 log units) below; low and high end bracket the measured number.
By their numbers in this assay, from the lowest: compounds 3, 2, 1 and 4 (each within the scatter of the next, the first and the last beyond it).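

In this assay the first read of this amide substituent, pyridin-3-yl in place of hydrogen on a saturated chain carbon bound to an amide-type nitrogen, gives a 2.7-fold higher number from compound 3 to compound 4 (0.43 log units; beyond the scatter) and so lies beyond the scatter. This place therefore responds to change, and here the larger group, with its six heavy atoms and one six-membered aromatic ring, moves the number up from that of compound 3 rather than leaving it flat. The data give no reason for this step.

Going by these compounds, whether the step belongs to the aromatic ring, to its ring nitrogen or to size alone stays open: phenyl, pyridin-4-yl or a plain propyl chain in the same place would separate these. Also open, on these data alone, is whether any group at this place brings the number below that of compound 3, for instance a smaller hydrogen-only primary amide or a chain ending in a carboxylic acid.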